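Notes on moving from 4-chlorophenyl to 2-chlorophenyl

The compounds below may be only part of what the source reports. "The series", "measured", "known", "first", "only" and "open" are said of these compounds alone.

- compound 1 (`O=S(=O)(Oc1ccccc1)C1CC2OC1C(c1ccc(/C=C/c3cc(O)cc(O)c3)cc1)=C2c1ccc(O)cc1`): 20100 nM
- compound 2 (`O=S(=O)(Oc1ccc(Cl)cc1)C1CC2OC1C(c1ccc(/C=C/c3cc(O)cc(O)c3)cc1)=C2c1ccc(O)cc1`): 17900 nM

In a functional assay on MCF7 cells (Homo sapiens) for antiproliferative activity, read by MTT assay, with a stated time of 72 h (on this read-out higher numbers stand for weaker inhibition and lower numbers for stronger inhibition), compound 2 cannot be separated from compound 1 (a 1.1-fold lower number from compound 1 to compound 2 (0.05 log units; within the scatter)). Compound 3 (`O=S(=O)(Oc1ccccc1Cl)C1CC2OC1C(c1ccc(/C=C/c3cc(O)cc(O)c3)cc1)=C2c1ccc(O)cc1`) carries 2-chlorophenyl in place of 4-chlorophenyl on an oxygen. For the measured compounds named here, only the step to compound 2 bears on this change, and it shows chloro in place of hydrogen leaving the number within the scatter (a 1.1-fold lower number from compound 1 to compound 2 (0.05 log units; within the scatter)). Going by the values given here, no measured compound yet carries 2-chlorophenyl. The change is estimated as a 1.0-fold higher number from compound 2 to compound 3 (0.00 log units; within the scatter), and no shift beyond the scatter is expected in either direction. Compound 3 is estimated at 18000 nM (expected range 9000 nM to 36000 nM).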

Compound 3, half-maximal inhibitory concentration: 40400 nM
Compound 3: the middle estimate sits 2.2-fold (0.35 log units) below what was measured, and the stated range ends below it.
By their numbers in this assay, from the lowest: compounds 2, 1 and 3 (each within the scatter of the next, the first and the last beyond it).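

In this assay, 2-chlorophenyl in place of 4-chlorophenyl on the oxygen gives a 2.3-fold higher number from compound 2 to compound 3 (0.35 log units; beyond the scatter), so the series shows a modest response to which chlorophenyl sits at this place. Chloro in place of hydrogen gives a 2.0-fold higher number from compound 1 to compound 3 (0.30 log units; within the scatter), so neither chlorophenyl compound separates from compound 1. No data here account for the difference between the two chlorophenyl groups. On these data alone, whether methoxy or an amine in place of the chloro of 2-chlorophenyl would give a similar step remains open.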